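A Styryl Group in Place of a Chlorophenyl Ring

The source may report more compounds than this note shows. Statements on the series, on what has been measured and on what is new or still open speak of the compounds shown alone.

Compound 1 `Cc1cc(O)c(C2=NN(c3ccc(S(N)(=O)=O)cc3)C(c3ccccc3O)C2)cc1Cl`: 8740 nM
Compound 2 `Cc1cc(O)c(C2=NN(c3ccc(S(N)(=O)=O)cc3)C(c3ccccc3Cl)C2)cc1Cl`: 7300 nM

In a functional assay on HCC 2998 cells (Homo sapiens) for antiproliferative activity, with a stated time of 48 h (on this read-out higher numbers stand for lower toxicity in this test and lower numbers for higher toxicity in this test), compound 2 carries the smaller of the two numbers, yet a 1.2-fold lower number from compound 1 to compound 2 (0.08 log units; within the scatter), so the two compounds cannot be told apart. Compound 3 `Cc1cc(O)c(C2=NN(c3ccc(S(N)(=O)=O)cc3)C(/C=C/c3ccccc3)C2)cc1Cl` differs from compound 2 by 2-phenylethenyl in place of 2-chlorophenyl on a saturated ring carbon. Among the measured compounds shown here, the single measured step concerned a different position and stayed within the scatter, so nothing measured bears directly on this exchange; no change beyond the scatter is expected. Compound 3 is therefore estimated at 7300 nM, with a range from 2400 nM to 22000 nM, which is expected to mean no change at the digits printed from compound 2 to compound 3 (within the scatter).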

Compound 3, concentration lethal to 50% of the cells: 92500 nM
Estimate against measurement, compound 3: 13-fold (1.10 log units) below, outside the stated range (above it).
By their numbers in this assay, from the lowest: compounds 2 and 1 (each within the scatter of the next); then compound 3.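

In this assay this saturated ring carbon proves sensitive to what it carries: 2-phenylethenyl gives a 13-fold higher number from compound 2 to compound 3 (1.10 log units; beyond the scatter) and also an 11-fold higher number from compound 1 to compound 3 (1.02 log units; beyond the scatter), both pointing to lower toxicity in this test. The hydroxy and chloro groups on the 2-substituted phenyl ring had left the number within the scatter, so only the change of the whole group moved it. Nothing measured here explains this rise. Still open, from the compounds shown here alone, is how an amine, a carboxylic acid or a longer carbon chain on this ring carbon would compare.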